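Methyl on the pyrimidine of the acrylamide series

This account rests on a few compounds, and the source may have more. Where it says the series, first, only, none or still open, it means among the compounds named here.

Measured compounds: compound 1 `COc1cc(N(C)CCN(C)C)c(NC(=O)C(Cl)=C(Cl)Cl)cc1Nc1nccc(-c2cn(C)c3ccccc23)n1`, compound 2 `CCC/C=C\C(=O)Nc1cc(Nc2nccc(-c3cn(C)c4ccccc34)n2)c(OC)cc1N(C)CCN(C)C`, compound 3 `CCC/C=C\C(=O)Nc1cc(Nc2ncc(C#N)c(-c3cn(C)c4ccccc34)n2)c(OC)cc1N(C)CCN(C)C`.

In a functional assay on HepG2 cells (Homo sapiens) for antiproliferative activity, read by MTT assay, with a stated time of 72 h (on this read-out higher numbers stand for weaker inhibition and lower numbers for stronger inhibition), compound 2 gives 431 nM. Compound 3 gives 1690 nM. Compound 1 gives only a limit, > 50000 nM, which is the limit of > 50000 nM in this assay, at which 1 of the 3 values shown sits. Among the two numbers shown, compound 2 stands lowest; the nearest is compound 3, and the step of a 3.9-fold higher number from compound 2 to compound 3 (0.59 log units; beyond the scatter) separates them.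

Compound 4 `CCC/C=C\C(=O)Nc1cc(Nc2nc(C)cc(-c3cn(C)c4ccccc34)n2)c(OC)cc1N(C)CCN(C)C` differs from compound 2 in one place: methyl in place of hydrogen on an aromatic carbon. The change sits on the same six-membered ring with two nitrogens that carries the cyano group of compound 3, so the step of a 3.9-fold higher number from compound 2 to compound 3 (0.59 log units; beyond the scatter) is the closest guide. The step of an at least 110-fold lower number from compound 1 to compound 2 (2.06 log units; beyond the scatter) concerns the carbonyl substituent and does not bear on the ring.

Methyl is a smaller group than cyano and brings no hydrogen-bond acceptor, so a shift smaller than that seen for compound 3 is expected, most likely toward a higher number, though a result within the scatter cannot be excluded. For compound 4 in this assay the estimate is 750 nM, within 280 nM to 2200 nM, which means an expected step of a 1.7-fold higher number from compound 2 to compound 4 (0.24 log units; within the scatter).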

Compound 4, half-maximal inhibitory concentration: 365 nM
For compound 4 the middle estimate is 2.1-fold (0.31 log units) above the measured one; measured number inside the range.
By their numbers in this assay, from the lowest: compounds 4 and 2 (each within the scatter of the next); then compound 3. At a limit, above all of these: compound 1.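

Working notes on the methyl position: in this assay, methyl in place of hydrogen on the aromatic carbon next to the ring nitrogen and meta to the 1-methyl-1H-indol-3-yl group gives a 1.2-fold lower number from compound 2 to compound 4 (0.07 log units; within the scatter), so the read-out does not separate the two compounds. Among these compounds, the only earlier change on this ring, cyano on a different aromatic carbon, gave a 3.9-fold higher number from compound 2 to compound 3 (0.59 log units; beyond the scatter); the new step shows that a substituent on this ring need not move the number beyond the scatter. Nothing measured here bears on why the methyl step stays within the scatter.

The steps to compound 3 and compound 4 differ in both the group and the carbon that carries it, so the compounds shown cannot say whether the contrast between them follows from the group, from its place, or from both. Also open, on these data alone, is how far this position accepts something larger than methyl, such as ethyl, methoxy, a dimethylamino group or a longer chain, and whether methyl on the carbon that carries the cyano group of compound 3 would behave as it does here.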